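The source may report more compounds than this note shows. Statements on the series, on what has been measured and on what is new or still open speak of the compounds shown alone.

Measured so far in a functional assay on CCRF-CEM cells for antagonist activity at C-X-C chemokine receptor type 4 (Homo sapiens), read by calcium flux, with stated times of 25 min and 90 s; a lower number here means a stronger inhibitor, a higher number a weaker inhibitor:
compound 1 `NC(=O)N1CCN(CCCN(C[C@H]2Cc3ccccc3CN2)[C@H]2CCCc3cccnc32)CC1` — 959 nM
compound 2 `c1ccc2c(c1)CN[C@@H](CN(CCCN1CCN(C3CC3)CC1)[C@H]1CCCc3cccnc31)C2` — 50 nM

Within the data shown here, compound 2 has the lower of the two numbers in this assay; its nearest neighbour is compound 1, and the only measured step, a 19-fold lower number from compound 1 to compound 2 (1.28 log units; beyond the scatter), is large and beyond the scatter.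

Compound 3 `c1ccc2c(c1)CN[C@@H](CN(CC[C@H]1CCCNC1)[C@H]1CCCc3cccnc31)C2` differs from compound 2 in one place: piperidin-3-yl in place of (4-cyclopropylpiperazin-1-yl)methyl on a saturated chain carbon, two bonds along the chain from an amine nitrogen. Among the measured compounds shown here, the one measured step concerns the substituent on the piperazine nitrogen, whereas here the whole (4-cyclopropylpiperazin-1-yl)methyl group is exchanged, so no measured step bears directly on this change. The step from compound 1 to compound 2 does show that this part of the molecule is sensitive to alteration. Compound 3 is therefore expected to give a higher number, with wide uncertainty. The expected step is a 5.0-fold higher number from compound 2 to compound 3 (0.70 log units; beyond the scatter). Compound 3 is estimated at 250 nM, in the range 50 nM to 1500 nM.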

Compound 3, half-maximal inhibitory concentration: 16 nM
The estimate for compound 3 lay 16-fold (1.19 log units) above the measured number; the measured number lies below the stated range.
By their numbers in this assay, from the lowest: compound 3; then compound 2; then compound 1.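

Notes on this position: in this assay, the piperazine ring is not required, as a 3.1-fold lower number from compound 2 to compound 3 (0.49 log units; beyond the scatter) when piperidin-3-yl, with fewer heavy atoms and a hydrogen-bond donor, replaces (4-cyclopropylpiperazin-1-yl)methyl. Against the carbamoyl-bearing group the same replacement gives a 60-fold lower number from compound 1 to compound 3 (1.78 log units; beyond the scatter), so the group on the saturated chain carbon can shift the number considerably in either comparison. No supporting data bear on why piperidin-3-yl does better here.

The compounds shown leave open whether the hydrogen on the piperidine nitrogen or the defined stereocentre accounts for the step from the piperazine group. An N-methylpiperidin-3-yl group, the opposite stereocentre or a piperidin-4-yl group would separate these features.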